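Swapping methoxy for fluoro on a galloyl-type catechol diester

The source may hold more compounds than are shown below. What is called first, only, known or untested is meant among the compounds shown, and "the series" means these compounds.

Compound 1 `COc1cccc(OC(=O)c2cc(O)c(O)c(O)c2)c1OC(=O)c1cc(O)c(O)c(O)c1`: 58.4%
Compound 2 `O=C(Oc1cccc(F)c1OC(=O)c1cc(O)c(O)c(O)c1)c1cc(O)c(O)c(O)c1`: 81.1%
Compound 3 `COc1cccc(OC(=O)c2cc(O)cc(O)c2)c1OC(=O)c1cc(O)cc(O)c1`: 69.4%

These three compounds were measured in a functional assay on NCI-H1299 cells (Homo sapiens) for inhibition, read by scintillation counting, with a stated time of 30 min, tested at 30 uM; a higher number here means more inhibition at the concentration tested (going by the name of the read-out), a lower number less inhibition. Compound 1 and compound 2 share one core, and the change between them is fluoro in place of methoxy on an aromatic carbon. That change gave a number 22.7 percentage points higher from compound 1 to compound 2 (beyond the scatter). Compound 3 has a different core, and the difference between the two cores is not broken down here. Compound 4 `O=C(Oc1cccc(F)c1OC(=O)c1cc(O)cc(O)c1)c1cc(O)cc(O)c1` is not yet measured; the change from compound 3 to compound 4 is fluoro in place of methoxy on an aromatic carbon, the same change as before, at the same place. Because the earlier step was a number 22.7 percentage points higher from compound 1 to compound 2 (beyond the scatter), a step of similar direction is expected here, though a number already high in this assay cannot rise as far. Compound 4 is therefore expected to give about 86% in this assay, between 72% and 97%, an estimated step of a number 16.6 percentage points higher from compound 3 to compound 4 (beyond the scatter).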

Compound 4, a percentage reported as inhibition, at one concentration (the size of the read-out at that concentration, not a potency): 94%
Beside the measured number, compound 4's estimate is 8 percentage points below it; low and high end bracket the measured number.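

Putting fluoro in place of methoxy on the second core gave, in this assay, a number 24.6 percentage points higher from compound 3 to compound 4 (beyond the scatter). The gain therefore carried from one core to the other with its size intact: the same change on two cores in this assay, a number 22.7 percentage points higher (beyond the scatter) from compound 1 to compound 2 and a number 24.6 percentage points higher (beyond the scatter) from compound 3 to compound 4, 1.9 percentage points apart, within the scatter of two such steps. This shows that the change transfers between these two cores at the one concentration tested, but it does not show how the compounds would compare in potency, nor that the same gain would appear on any other core.

The compounds shown leave open whether a different group at the same place, such as chloro, a nitrile or an amine, would match fluoro. They also leave open whether fluoro would help at another place on that ring.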